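Swapping the Amine on a Weak Antiproliferative Compound

This account rests on a few compounds, and the source may have more. Where it says the series, first, only, none or still open, it means among the compounds named here.

The three measured compounds share one core and differ only at the amine on the thiocarbonyl carbon or at one aromatic carbon. In a functional assay on HeLa cells (Homo sapiens) for antiproliferative activity, read by MTT assay, with a stated time of 72 h (a lower number here means a stronger inhibitor, a higher number a weaker inhibitor), compound 1 `O=c1cc(CSC(=S)N2CCCC2)oc2ccccc12` gives 23100 nM. Compound 2 `O=c1cc(CSC(=S)N2CCCC2)oc2cc(Cl)ccc12` reaches only a limit of the assay, > 40000 nM, so no exact number stands for it. The step of an at least 1.7-fold higher number from compound 1 to compound 2 (0.23 log units; that floor lies within the scatter) comes with chloro in place of hydrogen on an aromatic carbon. Compound 3 `CN(C(=S)SCc1coc2ccccc2c1=O)c1ccccc1` likewise sits at a limit, > 25000 nM. Compound 4 `CC(C)N(C(=S)SCc1cc(=O)c2ccc(Cl)cc2o1)C(C)C` keeps the chloro of compound 2 and changes the amine: diisopropylamino in place of pyrrolidin-1-yl on a thiocarbonyl carbon. Within the data shown here, no measured step covers this swap, and both measured amines give weak inhibition. Compound 4 is therefore expected to stay weak, with an estimated step of a number no higher from compound 2 to compound 4 (the limit leaves the size open) and an estimated value of 40000 nM, between 15000 nM and 100000 nM.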

Compound 4, half-maximal inhibitory concentration: > 30000 nM
Compound 4 was reported as a limit; the forecaster's own chance of this, stated with the estimate: 60%; the middle value is on the limit's open side.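

Compound 2 and compound 4 both stand only as limits, and the step between them cannot be read. The compounds shown leave open whether diisopropylamino or pyrrolidin-1-yl on a thiocarbonyl carbon gives the stronger inhibition.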